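The source may hold more compounds than are shown below. What is called first, only, known or untested is meant among the compounds shown, and "the series" means these compounds.

In an ADME assay on HepG2 cells (Homo sapiens) for cytotoxicity, read by neutral red uptake, with a stated time of 24 h; a higher number here means a weaker inhibitor, a lower number a stronger inhibitor:
Compound 1 `CC(=O)Oc1c(C(C)C)cc2c3c1OC(=O)[C@@]31CCCC(C)(C)[C@@H]1CC2`: 294000 nM
Compound 2 `CC(C)c1cc2c3c(c1OC(=O)CCl)OC(=O)[C@@]31CCCC(C)(C)[C@@H]1CC2`: 203000 nM
Compound 3 `CCCCCCCCCCCC(=O)Oc1c(C(C)C)cc2c3c1OC(=O)[C@@]31CCCC(C)(C)[C@@H]1CC2`: > 1000000 nM, a limit and not a number

Compound 3 stands at the top of the three, though only at a limit, (the limit of > 1000000 nM in this assay, at which 1 of the 3 values shown sits). Compound 4 `CCCCCCCC/C=C/CCCCCCCC(=O)Oc1c(C(C)C)cc2c3c1OC(=O)[C@@]31CCCC(C)(C)[C@@H]1CC2` changes the chain of compound 3: a group of 10 heavy atoms (10 carbon; no ring) in place of a group of 4 heavy atoms (4 carbon; no ring), on a saturated chain carbon, seven bonds along the chain from a carbonyl carbon. Within the data shown here, two measured steps bear on this: an at least 3.4-fold higher number from compound 1 to compound 3 (0.53 log units; beyond the scatter), and an at least 4.9-fold higher number from compound 2 to compound 3 (0.69 log units; beyond the scatter). The third, a 1.4-fold lower number from compound 1 to compound 2 (0.16 log units; within the scatter), involves no long chain. None of them shows what happens when an already long chain changes further, so no step beyond the scatter is expected. The estimated step is a step that the limit leaves unreadable from compound 3 to compound 4. Compound 4 is expected near 1500000 nM, with an estimated range of 600000 nM to 4000000 nM, and may well read as a limit too.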

Compound 4, half-maximal inhibitory concentration: > 1000000 nM
Compound 4 ended at the assay's limit; the forecaster's own chance of this, stated with the estimate: 75%; the middle value is on the limit's open side.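

Compound 3 and compound 4 both end at a limit and not at a number, so no step can be read between them: the limit of > 1000000 nM in this assay, at which 2 of the 4 values shown sit. The compounds shown leave open how these two long-chain esters actually compare.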